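The Same Change Applied to a Second Core

A few compounds are considered here, and "the series" means these few. Any claim that something is new, unique, unknown or untested is made for them only; others in the source may bear on it.

Of the compounds shown here, three have been measured in a functional assay on the whole organism with Rattus norvegicus as the target; a higher number here means that more compound is needed for the effect, a lower number that less compound is needed. Compound 1, `CCOCCOC(=O)C(=O)Nc1nc(-c2cc(C)no2)cs1`, gives 1.3 mg/kg. Compound 2, `CCOCCOC(=O)C(=O)Nc1nc(-c2cc(C)on2)cs1`, shares all its atoms with compound 1 but joins them differently: the difference between the two cores is 5-methyl-1,2-oxazol-3-yl in place of 3-methyl-1,2-oxazol-5-yl on an aromatic carbon, and the step it made was a 1.5-fold higher number from compound 1 to compound 2 (0.19 log units; within the scatter), so the two values cannot be told apart on this evidence. Compound 3, `Cc1cc(-c2csc(NC(=O)C(=O)O)n2)on1`, gives 6 mg/kg.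

Compound 3 arises from compound 1 by one change, (hydrogen in place of 2-ethoxyethyl on an oxygen next to a carbonyl group), and that change cost a 4.6-fold higher number from compound 1 to compound 3 (0.66 log units; beyond the scatter). Compound 4, `Cc1cc(-c2csc(NC(=O)C(=O)O)n2)no1`, has not yet been measured. It arises from compound 2 by hydrogen in place of 2-ethoxyethyl on an oxygen next to a carbonyl group, which is the same change at the same place, only on the core of compound 2 rather than that of compound 1.

Going by the values given here, the expectation for compound 4 therefore rests on two things: compound 2 stands at 2 mg/kg, and the one precedent for the change is the step from compound 1 to compound 3, a 4.6-fold higher number from compound 1 to compound 3 (0.66 log units; beyond the scatter). If the change behaves alike on both cores, the step from compound 2 to compound 4 is expected to be a 4.5-fold higher number from compound 2 to compound 4 (0.65 log units; beyond the scatter) in this assay. On that basis compound 4 is estimated at 9 mg/kg, with a plausible range from 4 mg/kg to 20 mg/kg; a single precedent is a thin base, so the range is kept wide.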

Compound 4, dose for half-maximal effect: 17 mg/kg
For compound 4 the middle estimate is 1.9-fold (0.28 log units) below the measured one; low and high end bracket the measured number.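

In this assay, putting hydrogen in place of 2-ethoxyethyl on the core of compound 2 gave an 8.5-fold higher number from compound 2 to compound 4 (0.93 log units; beyond the scatter) and so moved the number in the same direction as on the core of compound 1. Set side by side, the two steps cannot be told apart in size: the same change on two cores in this assay, a 4.6-fold higher number (0.66 log units; beyond the scatter) from compound 1 to compound 3 and an 8.5-fold higher number (0.93 log units; beyond the scatter) from compound 2 to compound 4, 1.8-fold (0.27 log units) apart, within the scatter of two such steps. Within this series the change therefore carried from one core to the other, both steps lying beyond the scatter and pointing the same way, but this rests on a single pair of compounds for each core and shows neither that the change would behave alike on any further core nor what lies behind the shift.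

The compounds shown carry only 2-ethoxyethyl or hydrogen on that oxygen, so it remains open where a small methyl group or a longer alkyl chain would fall in this assay, and whether the number climbs gradually as the chain shortens or only once the chain is gone altogether. Going by these compounds, it also remains open how an amine in place of that oxygen, giving an amide at the same carbonyl, would read on either core.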